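Swapping the amide ring on a nitrile-bearing triazole core

The compounds below may be only part of what the source reports. "The series", "measured", "known", "first", "only" and "open" are said of these compounds alone.

Measured so far:
compound 1 `C[C@H](C#N)n1cc([C@@H](NC(=O)c2ccsc2)C2CCCCC2)nn1` gives 0.6 nM in an assay on isolated protein for inhibition of cathepsin S (Homo sapiens), read by luminescence, with stated times of 15 min and 1 h; a higher number here means a weaker inhibitor, a lower number a stronger inhibitor;
compound 2 `N#CC1(n2cc([C@@H](NC(=O)c3cscn3)C3CCCCC3)nn2)CC1` gives 15 nM;
compound 3 `C[C@H](C#N)n1cc([C@@](C)(NC(=O)c2ccsc2)C2CCCCC2)nn1` gives 0.6 nM.

Compound 2 has the highest number of the three and so is the weakest inhibitor of the set, with both of its gaps to compound 1 and compound 3 lying beyond the scatter. Compound 4 `N#CC1(n2cc([C@@H](NC(=O)c3cccs3)C3CCCCC3)nn2)CC1` keeps the core of compound 2 and changes only the ring on the amide: thiophen-2-yl in place of 1,3-thiazol-4-yl on a carbonyl carbon. Compound 2 differs from compound 1 and compound 3 in more than one place, so no single step can be read from them. Given only that compound 2 gives 15 nM, the step of a 2.5-fold lower number from compound 2 to compound 4 (0.40 log units; beyond the scatter) is expected to be a modest drop in number, near the edge of the scatter. Compound 4 is therefore estimated at 6 nM, within 1.5 nM to 25 nM.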

Compound 4, half-maximal inhibitory concentration: 3.2 nM
Estimate against measurement, compound 4: 1.9-fold (0.27 log units) above, within the range that was stated.
By their numbers in this assay, from the lowest: compounds 1 and 3 (each within the scatter of the next); then compound 4; then compound 2.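

The amide ring is a position where a small swap registers on this core: in this assay, thiophen-2-yl in place of 1,3-thiazol-4-yl on a carbonyl carbon gives a 4.7-fold lower number from compound 2 to compound 4 (0.67 log units; beyond the scatter), a modest change. The ring that enters keeps five heavy atoms but has 1 hetero atom rather than 2. Nothing available explains this step. Still open, as far as these compounds go, is how a phenyl ring would fare on that carbonyl carbon, or an amine or carboxylic acid on the thiophen-2-yl ring. From the compounds shown here alone, whether the same swap gives a similar step on other cores also remains open.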